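The source may hold more compounds than are shown below. What is called first, only, known or untested is meant among the compounds shown, and "the series" means these compounds.

Three compounds of the series have numbers in an assay on HEK293 cells for inhibition of Voltage-dependent T-type calcium channel subunit alpha-1G (Homo sapiens), read by patch clamp; on this read-out higher numbers stand for weaker inhibition and lower numbers for stronger inhibition. Compound 1 `CCCc1nc(-c2ccccc2)c(CNCCN2CCN(C(c3ccccc3)c3ccccc3)CC2)o1` gives 7470 nM, compound 2 `CCCc1nc(-c2ccccc2)c(CNCCN2CCN(c3ccccc3Cl)CC2)o1` gives 4370 nM, and compound 3 `CCCc1nc(-c2ccccc2)c(CNCCCN2CCN(c3ccccc3F)CC2)o1` gives 16100 nM. Compound 3 has the highest number of the three; compound 1 stands nearest to it and compound 2 furthest, and both gaps lie beyond the scatter. Compound 4 `CCCc1nc(-c2ccccc2)c(CNCCCN2CCN(c3ccc(F)cc3)CC2)o1` is not yet measured in this assay. It differs from compound 3 in one place: 4-fluorophenyl in place of 2-fluorophenyl on an amine nitrogen in a ring. Within the data shown here, no pair of measured compounds shows this change, so nothing measured here speaks to it. The step of a 1.2-fold lower number from compound 3 to compound 4 (0.09 log units; within the scatter) is expected to stay within the scatter, with no direction assigned. For compound 4 the estimate in this assay is 13000 nM, expected to fall between 5000 nM and 32000 nM.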

Compound 4, half-maximal inhibitory concentration: 3210 nM
For compound 4 the middle estimate is 4.0-fold (0.61 log units) above the measured one; the measured number lies below the stated range.
By their numbers in this assay, from the lowest: compounds 4, 2 and 1 (each within the scatter of the next, the first and the last beyond it); then compound 3.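

In this assay, among these compounds, the exchange of 2-fluorophenyl for 4-fluorophenyl on the amine nitrogen in a ring gives a 5.0-fold lower number from compound 3 to compound 4 (0.70 log units; beyond the scatter) and is the only single-place step so far. The two compounds have the same atoms, so the place of the fluorine on the phenyl alone is enough to move the number beyond the scatter.

On these data alone, whether 4-chlorophenyl, 4-methoxyphenyl or plain phenyl on that nitrogen would match 4-fluorophenyl stays open, as does the effect of a longer chain. No measurement at hand gives a reason for this step.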